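Aryl sulfone variation on the shared core

A few compounds are considered here, and "the series" means these few. Any claim that something is new, unique, unknown or untested is made for them only; others in the source may bear on it.

Three compounds share one core and differ only in the aryl group on the sulfonyl sulfur. In an assay on HeLa cells for displacement of a labelled ligand from 5-hydroxytryptamine receptor 6 (Homo sapiens) (a higher number here means a weaker inhibitor, a lower number a stronger inhibitor), compound 1 `O=S(=O)(c1ccccc1Cl)c1cn(C2CCCNC2)c2ncccc12` gives 3.7 nM, compound 2 `O=S(=O)(c1ccc(Cl)cc1)c1cn(C2CCCNC2)c2ncccc12` gives 7.6 nM and compound 3 `O=S(=O)(c1cccc(F)c1)c1cn(C2CCCNC2)c2ncccc12` gives 2.4 nM. Compound 3 has the lowest of the three numbers; its nearest neighbour is compound 1, within the scatter, and its furthest is compound 2, beyond the scatter. Among the steps, a 2.1-fold higher number from compound 1 to compound 2 (0.31 log units; beyond the scatter) and a 3.2-fold lower number from compound 2 to compound 3 (0.50 log units; beyond the scatter) are modest, while a 1.5-fold lower number from compound 1 to compound 3 (0.19 log units; within the scatter) is within the scatter.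

Compound 4 `O=S(=O)(c1cc(Cl)cc(Cl)c1)c1cn(C2CCCNC2)c2ncccc12` carries the change (3,5-dichlorophenyl in place of 3-fluorophenyl on a sulfonyl sulfur). Among the compounds with values here, no measured step involves two chlorines on this ring, and none involves a 3,5-dichlorophenyl group. What bears on the change is that exchanging one halogen for another, or placing a single chlorine differently, moved this assay only modestly, the largest shift being a 3.2-fold lower number from compound 2 to compound 3 (0.50 log units; beyond the scatter). A second chlorine is therefore expected to bring at most a modest shift in this assay, if any beyond the scatter, more likely toward a higher number than a lower one. Compound 4 is expected at 4.5 nM, with a range from 1.5 nM to 13 nM, which corresponds to an expected 1.9-fold higher number from compound 3 to compound 4 (0.27 log units; within the scatter).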

Compound 4, inhibition constant: 6.1 nM
Beside the measured number, compound 4's estimate is 1.4-fold (0.13 log units) below it, and the stated range covers the measured number.
By their numbers in this assay, from the lowest: compounds 3, 1, 4 and 2 (each within the scatter of the next, the first and the last beyond it).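

Within the data shown here, on a sulfonyl sulfur, the 3,5-dichlorophenyl group is the first aryl group in the set to carry two halogens, and in this assay it gives a 2.5-fold higher number from compound 3 to compound 4 (0.41 log units; beyond the scatter) as a modest step away from 3-fluorophenyl. Against the two chlorophenyl compounds, the second chlorine brings no separable change: the readings are a 1.2-fold lower number from compound 2 to compound 4 (0.10 log units; within the scatter) and a 1.6-fold higher number from compound 1 to compound 4 (0.22 log units; within the scatter) so this position tolerates the 3,5-dichlorophenyl group about as well as either single-chlorine group in this assay, and compound 3 remains apart from compound 4 and compound 2 only. No measurement at hand accounts for the shift from 3-fluorophenyl to 3,5-dichlorophenyl.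

The step from 3-fluorophenyl to 3,5-dichlorophenyl changes both the kind and the number of halogens, and the compounds shown do not separate these two changes. Going by these compounds, it also remains open how this assay would respond on this aryl ring to a group other than a halogen, such as a methoxy group, a nitrile or an amine.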